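Working notes on compounds 1 to 4 of the series

A few compounds are considered here, and "the series" means these few. Any claim that something is new, unique, unknown or untested is made for them only; others in the source may bear on it.

Values in an ADME assay on HEK293 cells (Homo sapiens) for cytotoxicity, read by CellTiter-Glo and resazurin assay, with a stated time of 72 h; on this read-out lower numbers stand for an effect already at smaller amounts and higher numbers for an effect only at larger amounts of compound:
compound 1 `CCOC(=O)CCCCCOc1cccc(CN(C(=O)c2ccc(-c3cccnc3)cc2)C(C)C)c1` – a limit of the assay, > 26000 nM
compound 2 `CCOC(=O)CCCCCOc1cccc(CN(C(=O)c2ccc(-c3cccc(OC)c3)cc2)C(C)C)c1` – a limit of the assay, > 21000 nM
compound 3 `CCOC(=O)CCCCCOc1cccc(CN(C(=O)c2ccc(-c3ccc4c(c3)OCCO4)cc2)C(C)C)c1` – a limit of the assay, > 24400 nM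

Compound 3 stands at a limit in this assay. The two further values shown are limits as well, so no order among compounds 1, 2 and 3 can be read. The steps a step that the two limits leave unreadable from compound 1 to compound 2, a step that the two limits leave unreadable from compound 1 to compound 3 and a step that the two limits leave unreadable from compound 2 to compound 3 are therefore of unreadable size and direction; this follows from the limit of > 21000 nM in this assay, at which 1 of the 3 values shown sits, the limit of > 24400 nM in this assay, at which 1 of the 3 values shown sits, and (the limit of > 26000 nM in this assay, at which 1 of the 3 values shown sits).

Compound 4 `CCOC(=O)CCCCCOc1cccc(CN(C(=O)c2ccc(Br)cc2)C(C)C)c1` differs from compound 3 by bromo in place of 2,3-dihydro-1,4-benzodioxin-6-yl on an aromatic carbon. The measured steps that bear on a swap at this aromatic carbon are the three above, and none of them yields a readable size. Within the data shown here, what the three compounds show is only that the shared core with three different groups at this carbon reaches a limit in this assay each time. Compound 4 is therefore expected to give a step that the limit leaves unreadable from compound 3 to compound 4, that is, none beyond the scatter, and most probably a limit again. The estimate for compound 4 is 25000 nM, with a range from 10000 nM to 60000 nM.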

Compound 4, half-maximal effective concentration: > 26000 nM
Compound 4 was reported as a limit (the forecaster's own chance of this, stated with the estimate: 75%); middle value at least 1.0-fold (0.01 log units) away from the limit.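

In this assay compound 4 gives > 26000 nM, which is a limit of the assay. Compounds 1, 2 and 3 also stand at limits, so none of their steps to compound 4 can be read. Still open, from the compounds shown here alone, is the half-maximal effective concentration of each of the four compounds, and whether swapping the group on this aromatic carbon changes it at all.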